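The source may hold more compounds than are shown below. What is called first, only, known or untested is meant among the compounds shown, and "the series" means these compounds.

Compound 1 `CCOc1ccc(NC2=CC(=O)c3c(nc4n3[C@H]3OC[C@@H](O)[C@H]3OC4)C2=O)cc1`: 14400 nM
Compound 2 `CCOc1ccccc1NC1=CC(=O)c2c(nc3n2[C@H]2OC[C@@H](O)[C@H]2OC3)C1=O`: 8300 nM
Compound 3 `Cc1ccc(NC2=CC(=O)c3c(nc4n3[C@H]3OC[C@@H](O)[C@H]3OC4)C2=O)cc1`: 6590 nM

In a functional assay on HeLa cells (Homo sapiens) for inhibition, read by sulforhodamine B assay (a higher number here means a weaker inhibitor, a lower number a stronger inhibitor), compound 3 gives the lowest of the three numbers. Its nearest neighbour is compound 2, whose value sits within the scatter of it, while compound 1 lies furthest, with a gap that is beyond the scatter. Compound 4 `O=C1C(N2CCC2)=CC(=O)c2c1nc1n2[C@H]2OC[C@@H](O)[C@H]2OC1` differs from compound 3 in one place: azetidin-1-yl in place of (4-methylphenyl)amino on a double-bonded ring carbon.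

The measured steps speak to this change only indirectly. The step of a 1.7-fold lower number from compound 1 to compound 2 (0.24 log units; within the scatter) and the step of a 1.3-fold lower number from compound 2 to compound 3 (0.10 log units; within the scatter) both alter the group on the aryl ring of the anilino substituent, and both stay within the scatter, so changes at that ring have so far moved the numbers little. The step of a 2.2-fold lower number from compound 1 to compound 3 (0.34 log units; beyond the scatter) is modest. Within the data shown here, no measured pair, however, removes the (4-methylphenyl)amino group altogether or puts a small saturated ring amine in its place, so the series gives no direct guide for compound 4.

Compound 4 is therefore expected to give a number in this assay near 15000 nM, plausibly between 4000 nM and 60000 nM, and the step of a 2.3-fold higher number from compound 3 to compound 4 (0.36 log units; beyond the scatter) is an estimate, leaning toward a weaker inhibitor with wide uncertainty.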

Compound 4, half-maximal inhibitory concentration: > 16000 nM
Compound 4: a limit, no number; the forecaster's own chance of this, stated with the estimate: 20%; middle value at least 1.0-fold (0.02 log units) from the limit.
By their numbers in this assay, from the lowest: compounds 3, 2 and 1 (each within the scatter of the next, the first and the last beyond it). At a limit, above all of these: compound 4.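

Compound 4 stands at a limit and not at a number in this assay: the limit of > 16000 nM in this assay, at which 1 of the 4 values shown sits.

Azetidin-1-yl in place of (4-methylphenyl)amino on the double-bonded ring carbon gives an at least 2.4-fold higher number from compound 3 to compound 4 (0.38 log units; beyond the scatter), so replacing the whole substituent moves the result beyond the scatter and toward a weaker inhibitor. Among these compounds, the earlier steps only altered the group on the aryl ring, and the largest of them was modest, so compound 4 is the first to show that this position tolerates less when the (4-methylphenyl)amino group is lost entirely than when that ring is merely redecorated.

The change takes away the aromatic ring and the amine hydrogen together and also shortens the substituent, so the compounds shown cannot say which of these differences matters. A cyclohexylamino group, which keeps the amine hydrogen without the aromatic ring, or an N-methyl-4-methylanilino group, which keeps the aromatic ring without that hydrogen, would pull these apart, and a piperidin-1-yl ring would show whether a larger saturated ring amine behaves as azetidin-1-yl does.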